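A Ring Swap at the Limit of a Toxicity Test

A few compounds are considered here, and "the series" means these few. Any claim that something is new, unique, unknown or untested is made for them only; others in the source may bear on it.

Compound 1 `CN1C(=S)[C@@H](NC(=O)c2nc(Cc3ccccc3)n(C3COC3)n2)COc2ccccc21` and compound 2 `CN1C(=S)[C@@H](NC(=O)c2nc(Cc3ccccc3)n(CC3CCOCC3)n2)COc2ccccc21` share one core. In a toxicity assay on HT-29 cells (Homo sapiens) for cytotoxicity (on this read-out higher numbers stand for lower toxicity in this test and lower numbers for higher toxicity in this test), compound 1 gives > 100000 nM as a limit of the assay, not a number. In this assay compound 2 gives > 100000 nM, which is again a limit. The series therefore stands at the limit of > 100000 nM in this assay, at which 2 of the 2 values shown sit, and compound 2 has no readable position within it.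

Compound 3 `CN1C(=S)[C@@H](NC(=O)c2nc(Cc3ccccc3)n(C3CCNC3)n2)COc2ccccc21` keeps the core of compound 2 but carries pyrrolidin-3-yl in place of (oxan-4-yl)methyl on an aromatic nitrogen, next to the ring atom that bears a benzyl group. The counted difference is pyrrolidin-3-yl in place of (oxan-4-yl)methyl on an aromatic nitrogen. For the measured compounds named here, the only measured change at this position is a step that the two limits leave unreadable from compound 1 to compound 2, so it offers no size to carry over, only the observation that both groups left the read-out at the limit. No change beyond the usual scatter is therefore expected, and no direction can be assigned. The expected change is a number no higher from compound 2 to compound 3 (the limit leaves the size open), and the assay may well report only a limit again. The estimate for compound 3 is 100000 nM, within an expected range of 30000 nM to 300000 nM.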

Compound 3, half-maximal cytotoxic concentration: > 100000 nM
Compound 3 gave a limit, no number (the forecaster's own chance of this, stated with the estimate: 85%); the middle value sits exactly at the limit.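

For the compounds shown here, compound 3 gives only a limit in this assay, so no step among compound 1, compound 2 and compound 3 can be read, and the series stands here: the limit of > 100000 nM in this assay, at which 3 of the 3 values shown sit.

The compounds shown leave open whether oxetan-3-yl, (oxan-4-yl)methyl and pyrrolidin-3-yl differ at all in this assay, and whether any group on this aromatic nitrogen would give a readable number.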